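This account rests on a few compounds, and the source may have more. Where it says the series, first, only, none or still open, it means among the compounds named here.

Compound 3 (`CC(=O)NCc1cccc(Cn2nc(NS(=O)(=O)c3ccc(Cl)s3)c3c(C#N)cccc32)c1`) gives >= 155 ug/mL in a physicochemical assay for solubility, read by chemiluminescence, measured as kinetic solubility (a lower number here means a less soluble compound, a higher number a more soluble compound), a limit and not a number. Compound 1 (`CC(=O)NCc1cccc(Cn2nc(NS(=O)(=O)c3ccc(Cl)s3)c3c(Cl)cccc32)c1`) gives >= 226 ug/mL, also a limit. Compound 2 (`CC(=O)NCc1cccc(Cn2nc(NS(=O)(=O)c3ccc(Cl)s3)c3c(O)cccc32)c1`) gives >= 166 ug/mL, again a limit. Compound 4 (`CC(=O)NCc1cccc(Cn2nc(NS(=O)(=O)c3ccc(Cl)s3)c3c(C(C)=O)cccc32)c1`) carries acetyl in place of cyano on an aromatic carbon. Among the compounds with values here, three measured steps bear on this aromatic carbon: a step that the two limits leave unreadable from compound 1 to compound 2, a step that the two limits leave unreadable from compound 1 to compound 3 and a step that the two limits leave unreadable from compound 2 to compound 3. None of them gives a size to carry over. Going by compound 3 and (the limit of >= 155 ug/mL in this assay, at which 1 of the 3 values shown sits), no step beyond the scatter is expected in this assay, and no direction can be called. The expected step is a step that the limit leaves unreadable from compound 3 to compound 4. For compound 4 the estimate is 180 ug/mL, with an expected range of 110 ug/mL to 250 ug/mL.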

Compound 4, solubility: 57 ug/mL
Compound 4: middle estimate off by 3.2-fold (0.50 log units), on the high side; the measured number lies below the stated range.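

In this assay, this aromatic carbon now shows a readable change: acetyl in place of cyano gives an at least 2.7-fold lower number from compound 3 to compound 4 (0.43 log units; beyond the scatter), in place of hydroxy an at least 2.9-fold lower number from compound 2 to compound 4 (0.46 log units; beyond the scatter), and in place of chloro an at least 3.9-fold lower number from compound 1 to compound 4 (0.59 log units; beyond the scatter). Within the data shown here, the steps among compound 1, compound 2 and compound 3 cannot be read, so these are the first sizes for this position. Each size is a floor, as each step starts from a limit.

Going by these compounds, how far compound 1, compound 2 and compound 3 lie past their limits stays open. Also open, on these data alone, is whether a carboxylic acid, an amine or a longer ketone chain on this carbon would follow acetyl.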